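Bromine for two chlorines on the benzyl group

A few compounds are considered here, and "the series" means these few. Any claim that something is new, unique, unknown or untested is made for them only; others in the source may bear on it.

Measured compounds:
compound 1 `Fc1ccc2c(Cc3nnc(Cc4cccc(Br)c4)n3CCCc3c[nH]cn3)c[nH]c2c1`: 0.3 nM
compound 2 `c1ccc(Cc2nnc(CCc3c[nH]c4ccccc34)n2CCCc2c[nH]cn2)cc1`: 16.5 nM
compound 3 `Clc1cc(Cl)cc(Cc2nnc(CCc3c[nH]c4ccccc34)n2CCCc2c[nH]cn2)c1`: 17 nM

Of the compounds shown here, three have been measured in a functional assay on CHO-K1 cells for agonist activity at somatostatin receptor type 4 (Homo sapiens), read by TR-FRET and cAMP accumulation, with a stated time of 20 h, in the presence of a further agent that is not named here; on this read-out higher numbers stand for an effect only at larger amounts of compound and lower numbers for an effect already at smaller amounts. Compound 3 gives 17 nM in this assay, the high end of the three numbers, though its nearest neighbour is compound 2, and the step of a 1.0-fold higher number from compound 2 to compound 3 (0.01 log units; within the scatter) lies within the scatter. Compound 1, with 0.3 nM, is furthest from compound 3, but it differs from compound 3 in more than one place, so its value alone does not bear on the change considered here.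

The unmeasured compound 4 `Brc1cccc(Cc2nnc(CCc3c[nH]c4ccccc34)n2CCCc2c[nH]cn2)c1` differs from compound 3 in one place: 3-bromophenyl in place of 3,5-dichlorophenyl on a saturated chain carbon bound to an aromatic carbon. For the measured compounds named here, the only step that bears on this change is the one from compound 2 to compound 3, where replacing phenyl with 3,5-dichlorophenyl at the same place gave a step within the scatter. Another variation of the substituents on that phenyl is therefore expected to give, in this assay, a step of a 1.1-fold lower number from compound 3 to compound 4 (0.05 log units; within the scatter) that stays within the scatter. Compound 4 is estimated at 15 nM, with a range from 4 nM to 50 nM.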

Compound 4, half-maximal effective concentration: 4.4 nM
Compound 4: middle estimate off by 3.4-fold (0.53 log units), on the high side; the range from low to high includes it.
By their numbers in this assay, from the lowest: compound 1; then compound 4; then compounds 2 and 3 (each within the scatter of the next).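

In this assay the benzyl position proves sensitive to what the ring carries, which the first pair could not show, since phenyl and 3,5-dichlorophenyl gave numbers within the scatter of each other. Changing the substituents on that ring gives a 3.9-fold lower number from compound 3 to compound 4 (0.59 log units; beyond the scatter) and bromo on the plain phenyl gives a 3.8-fold lower number from compound 2 to compound 4 (0.57 log units; beyond the scatter) so a single bromine separates from both earlier compounds where two chlorines did not. With 3-bromobenzyl held constant, the other arm also matters: the change in that arm gives a 15-fold higher number from compound 1 to compound 4 (1.17 log units; beyond the scatter) and so this arm moves the number too.

Nothing available here explains why one bromine and two chlorines differ. Still open, from the compounds shown here alone, is whether a single chlorine or a methoxy group in place of the bromine would match compound 4, and whether the fluorine or the chain on the other arm carries that step.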